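Working notes: three limits and an untested fourth compound

A few compounds are considered here, and "the series" means these few. Any claim that something is new, unique, unknown or untested is made for them only; others in the source may bear on it.

compound 1 `CC(=O)NCC(=O)Nc1ccc(Cl)cc1C(=O)c1ccccc1` — in a functional assay on the whole organism with Mus musculus as the target, in the rotarod test (a higher number here means that more compound is needed for the effect, a lower number that less compound is needed), compound 1 gives > 100 mg/kg, which is a limit of the assay and not a number.
compound 2 `CN(C(=O)CNC(=O)c1ccccc1)c1ccc(Cl)cc1C(=O)c1ccccc1Cl` — in this assay compound 2 gives > 100 mg/kg, a limit of the assay.
compound 3 `CC(=O)NCC(=O)Nc1ccc(Cl)cc1C(=O)c1ccccc1Cl` — in this assay compound 3 gives > 100 mg/kg, a limit of the assay.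

All three measured values sit at the same limit (the limit of > 100 mg/kg in this assay, at which 3 of the 3 values shown sit), so none of the three compounds can be ordered against another. The change from compound 3 to compound 1 is hydrogen in place of chloro on an aromatic carbon. The step that the two limits leave unreadable from compound 3 to compound 1 is one that the two limits leave unreadable, so its size is not known. The difference between the core of compound 2 and the core of compound 3 is not broken down here.

Compound 4 `CN(C(=O)CNC(=O)c1ccccc1)c1ccc(Cl)cc1C(=O)c1ccccc1` has not yet been measured in this assay. It differs from compound 2 by hydrogen in place of chloro on an aromatic carbon. The place lines of this change and of the change from compound 3 to compound 1 read the same word for word, so it is the same kind of change, made on a different core. The expectation for compound 4 rests only on compound 2 sitting at the limit > 100 mg/kg and on the measured pair giving no readable size for the change. The step from compound 2 to compound 4 is estimated as a step that the limit leaves unreadable from compound 2 to compound 4, a small one in view of the unreadable step that the two limits leave unreadable from compound 3 to compound 1. Compound 4 is therefore expected to give about 150 mg/kg, between 60 mg/kg and 400 mg/kg, and most likely to be reported again only as a limit.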

Compound 4, dose for half-maximal effect: > 100 mg/kg
Compound 4: only a limit was reported (the forecaster's own chance of this, stated with the estimate: 85%); the middle value lies beyond the limit too.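

In this assay no new step can be read between compound 2 and compound 4, since both values are limits of the assay and not numbers: the limit of > 100 mg/kg in this assay, at which 4 of the 4 values shown sit.

The compounds shown leave open where the half-maximal dose of any of them lies, and how large the change from 2-chlorophenyl to phenyl is on either core.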